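A few compounds are considered here, and "the series" means these few. Any claim that something is new, unique, unknown or untested is made for them only; others in the source may bear on it.

Working notes on the aryl-hydrazone series.

Compound 1 `COc1ccc(/C=N/NC(=O)Nc2ccc(Oc3ccnc(-c4nncn4CCN(C)C)c3)c(F)c2)c(OC)c1OC` gives 2020 nM in a functional assay on MKN-45 cells (Homo sapiens) for cytotoxicity, read by MTT assay, with a stated time of 72 h; a lower number here means a stronger inhibitor, a higher number a weaker inhibitor. Compound 2 `CN(C)CCn1cnnc1-c1cc(Oc2ccc(NC(=O)N/N=C/c3ccc(O)cc3O)cc2F)ccn1` gives 2860 nM in this assay. Going by the values given here, the single one-place step measured so far is a 1.4-fold higher number from compound 1 to compound 2 (0.15 log units; within the scatter), so the two values cannot be ordered against each other. Compound 2 therefore stands on equal footing with compound 1 as far as the two numbers show; nothing else has been measured in this assay.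

Compound 3 `CN(C)CCn1cnnc1-c1cc(Oc2ccc(NC(=O)N/N=C/c3cccc(O)c3)cc2F)ccn1` differs from compound 2 in one place: 3-hydroxyphenyl in place of 2,4-dihydroxyphenyl on a carbon with a double bond to nitrogen. Among the compounds with values here, no measured step exchanges a hydroxyphenyl pattern for another, so only the step from compound 1 to compound 2 bears on the change at all, and it shows that a different aryl on the carbon with a double bond to nitrogen left the number within the scatter. On that basis the expected step from compound 2 to compound 3 in this assay is a 1.0-fold higher number from compound 2 to compound 3 (0.02 log units; within the scatter), no clear direction beyond the scatter. Compound 3 is accordingly estimated at 3000 nM in this assay, with a range from 1200 nM to 7500 nM.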

Compound 3, half-maximal inhibitory concentration: 1370 nM
The estimate for compound 3 lay 2.2-fold (0.34 log units) above the measured number; the range from low to high includes it.
By their numbers in this assay, from the lowest: compounds 3, 1 and 2 (each within the scatter of the next, the first and the last beyond it).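

In this assay, going by these compounds alone, replacing 2,4-dihydroxyphenyl with 3-hydroxyphenyl on a carbon with a double bond to nitrogen gives a 2.1-fold lower number from compound 2 to compound 3 (0.32 log units; beyond the scatter), the first step at this position to lie beyond the scatter, though it is modest, so the aryl group here can move the number. Replacing 2,3,4-trimethoxyphenyl with the same 3-hydroxyphenyl gives a 1.5-fold lower number from compound 1 to compound 3 (0.17 log units; within the scatter), which is within the scatter, so compound 3 cannot be ordered against compound 1, and the only separation in the series is that between compound 2 and compound 3. No measurement accompanies these numbers that could account for the step.

The step from 2,4-dihydroxyphenyl to 3-hydroxyphenyl changes the number of hydroxyl groups and their pattern at once, going from 2 hydrogen-bond donors to 1, so the compounds shown do not separate the two changes. On these data alone, it also remains open how an aryl group carrying an amine or a carboxylic acid in place of the hydroxyl would read in this assay, and whether any such group would reach beyond the scatter of compound 3.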